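The compounds below may be only part of what the source reports. "The series", "measured", "known", "first", "only" and "open" are said of these compounds alone.

Compound 1 `CCCNc1cnn(C)c(=O)c1OCC` and compound 2 `C=CCN(CC=C)c1cnn(C)c(=O)c1OCC` share one core and have both been tested in a functional assay on the whole organism (strain Wistar) for inhibition, with Rattus norvegicus as the target, read by paw edema, with stated times of 30 min and 3 h, at a dose of 50 mg/kg by the oral route; a lower number here means a weaker effect, a higher number a stronger effect of the compound at the dose given. In this assay compound 1 gives 8%, the higher of the two numbers, while compound 2 gives -5.2%, a gap that lies beyond the usual scatter. These two compounds differ in more than one place. Among the measured compounds shown here, no single-change step between them can be read. The unmeasured compound 3 `CCOc1c(N2CCCC2)cnn(C)c1=O` differs from compound 1 by one change: pyrrolidin-1-yl in place of propylamino on an aromatic carbon. For the measured compounds named here, nothing measured so far isolates this change, and compound 1, at 8%, as well as compound 2, at -5.2%, have given only small numbers in this assay. The step from compound 1 to compound 3 is expected to be small and downward, a number 6 percentage points lower from compound 1 to compound 3 (within the scatter), not clearly beyond the scatter. Compound 3 is therefore estimated to give 2% in this assay, with a range from -12% to 16%.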

Compound 3, a percentage reported as inhibition, in the whole organism at one dose (the size of the read-out at that dose, not a potency): -2.3%
The estimate for compound 3 lay 4.3 percentage points above the measured number, within the range that was stated.
By their numbers in this assay, from the lowest: compounds 2 and 3 (each within the scatter of the next); then compound 1.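

In this assay, among the compounds shown here, pyrrolidin-1-yl in place of propylamino on the aromatic carbon gives the first single change that can be read at this position: a number 10.3 percentage points lower from compound 1 to compound 3 (beyond the scatter), a modest step. The position therefore responds to the group it carries, although the change, which takes away the hydrogen-bond donor of propylamino and adds a five-membered ring, leaves both numbers small. Nothing available explains this step, and it cannot be assigned to the lost donor or to the ring.

The compounds shown leave open whether the donor or the ring matters more; diethylamino, an open chain without the amine hydrogen, would help separate the two. Also open, from the compounds shown here alone, is whether butylamino or a morpholine ring at this position would move the number in this assay beyond that of compound 1, at 8%.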